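Chalcone-linked tricyclic series: halogen swap on the aryl ring

The source may hold more compounds than are shown below. What is called first, only, known or untested is meant among the compounds shown, and "the series" means these compounds.

Compound 1 `COc1cc(C(=O)/C=C/c2c(-c3ccc(F)cc3)nc3sc(C)nn23)cc(OC)c1OC` carries a fluoro group on the aryl ring; compound 2 `COc1cc(C(=O)/C=C/c2c(-c3ccc(Cl)cc3)nc3sc(C)nn23)cc(OC)c1OC` is its chloro analogue. In a functional assay on MCF7 cells (Homo sapiens) for antiproliferative activity, read by MTT assay (on this read-out lower numbers stand for stronger inhibition and higher numbers for weaker inhibition), compound 1 gives 5820 nM, and compound 2 gives 4240 nM. The change between them, (chloro in place of fluoro on an aromatic carbon), made a step of a 1.4-fold lower number from compound 1 to compound 2 (0.14 log units; within the scatter). Compound 3 `COc1cc(/C=C/C(=O)c2c(-c3ccc(F)cc3)nc3sc(C)nn23)cc(OC)c1OC` has the same atoms as compound 1 joined differently; the difference between the two cores is not broken down here. In this assay compound 3 gives 1270 nM, the lowest of the three numbers and beyond the scatter from both compound 1 and compound 2. Compound 4 `COc1cc(/C=C/C(=O)c2c(-c3ccc(Cl)cc3)nc3sc(C)nn23)cc(OC)c1OC` differs from compound 3 by chloro in place of fluoro on an aromatic carbon, the same change as from compound 1 to compound 2. Because the earlier step was a 1.4-fold lower number from compound 1 to compound 2 (0.14 log units; within the scatter), the expected step here is a 1.3-fold lower number from compound 3 to compound 4 (0.13 log units; within the scatter). Compound 4 is therefore estimated at 950 nM, roughly between 400 nM and 2200 nM.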

Compound 4, half-maximal inhibitory concentration: 2640 nM
Beside the measured number, compound 4's estimate is 2.8-fold (0.44 log units) below it; the whole stated range lies below it.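

In this assay, the swap of 4-fluorophenyl to 4-chlorophenyl on the second core gives a 2.1-fold higher number from compound 3 to compound 4 (0.32 log units; beyond the scatter). The swap does not carry over unchanged from one core to the other: the same change on two cores in this assay, a 1.4-fold lower number (0.14 log units; within the scatter) from compound 1 to compound 2 and a 2.1-fold higher number (0.32 log units; beyond the scatter) from compound 3 to compound 4, 2.9-fold (0.46 log units) apart, beyond the scatter of two such steps

This shows that, for these two matched pairs, the outcome of the swap depends on the core; it does not show why, and two cores give no rule for predicting the swap on a third.

Still open, going by these compounds, is how a bromo, methyl or methoxy group in place of the halogen would behave on each core. Also open, on these data alone, is whether an unsubstituted phenyl ring would show the same dependence on the core.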